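The compounds below may be only part of what the source reports. "The series", "measured", "known", "first", "only" and "open" are said of these compounds alone.

In an assay on CHO cells for displacement of a labelled ligand from adenosine receptor A1 (Homo sapiens), read by scintillation counting, with a stated time of 90 min, tested at 1 uM (a higher number here means more inhibition at the concentration tested (going by the name of the read-out), a lower number less inhibition), the measured compounds are:

compound 1 `CC(=O)Nc1ccc(-c2c(C#N)c(N)nc(SCC(N)=O)c2C#N)cc1`, 17%
compound 2 `N#Cc1c(N)nc(SCc2nnn[nH]2)c(C#N)c1-c1ccc(OCC2CC2)cc1`, 3%
compound 3 `N#Cc1c(N)nc(SCn2cncn2)c(C#N)c1-c1ccc(OCC2CC2)cc1`, 12%

On these numbers compound 3 is second highest of the three, but its gap to compound 1 and its gap to compound 2 are both within the scatter. Compound 4 `CNC(=O)CSc1nc(N)c(C#N)c(-c2ccc(OCC3CC3)cc2)c1C#N` has not yet been measured. It differs from compound 3 by methylcarbamoyl in place of 1H-1,2,4-triazol-1-yl on a saturated chain carbon bound to a sulfur. Going by the values given here, the one measured step, a number 9 percentage points higher from compound 2 to compound 3 (within the scatter), exchanged one ring for another at the same carbon and stayed within the scatter. Compound 1 carries a related amide chain but differs elsewhere as well, so its value shows only that such a chain also sits in this low region. Compound 4 is therefore expected to give 15%, between 4% and 28%, an expected step of a number 3 percentage points higher from compound 3 to compound 4 (within the scatter), none beyond the scatter.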

Compound 4, a percentage reported as inhibition, at one concentration (the size of the read-out at that concentration, not a potency): 14%
Compound 4: the middle estimate sits 1 percentage points above what was measured, and the stated range covers the measured number.
By their numbers in this assay, from the lowest: compounds 2, 3, 4 and 1 (each within the scatter of the next, the first and the last beyond it).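

In this assay, the step of a number 2 percentage points higher from compound 3 to compound 4 (within the scatter) shows that methylcarbamoyl, with no ring, cannot be told apart from 1H-1,2,4-triazol-1-yl on a saturated chain carbon bound to a sulfur. Going by these compounds alone, replacing 1H-tetrazol-5-yl at that place gives a number 11 percentage points higher from compound 2 to compound 4 (beyond the scatter) and is the first step at this position to pass the scatter, though only modestly. Nothing shown gives a reason for either step. Still open, going by these compounds, is whether an amine, a carboxylic acid or a longer chain on this carbon would leave this low range of inhibition.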